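Moving a Halogen on the Benzyl Group of Compound 2

A few compounds are considered here, and "the series" means these few. Any claim that something is new, unique, unknown or untested is made for them only; others in the source may bear on it.

Compound 2 `COc1ccc(C(=O)/C=C/c2ccc(OCc3cn(Cc4ccc(Br)cc4)nn3)cc2)cc1` is the lower of the two chalcones measured so far. In a functional assay on MCF7 cells (Homo sapiens) for inhibition, read by MTT assay, with a stated time of 48 h, tested at 10 uM (a lower number here means less inhibition of growth, a higher number more inhibition of growth at the concentration tested), compound 2 gives 53%. Among the compounds with values here, its only neighbour is compound 1 `COc1ccc(C(=O)/C=C/c2ccc(OCc3cn(Cc4ccccc4Br)nn3)cc2)cc1`, which in this assay gives 60%; the step of a number 7 percentage points lower from compound 1 to compound 2 (within the scatter), so the two cannot be ranked against each other. Compound 3 `COc1ccc(C(=O)/C=C/c2ccc(OCc3cn(Cc4ccccc4F)nn3)cc2)cc1` is not yet measured. It differs from compound 2 by 2-fluorophenyl in place of 4-bromophenyl on a saturated chain carbon bound to an aromatic nitrogen; cut one bond further out, the change reads 4-bromobenzyl to 2-fluorobenzyl. Within the data shown here, the one measured step that bears on this is the move from compound 1 to compound 2, which shifted the halogen on the same ring and produced a number 7 percentage points lower from compound 1 to compound 2 (within the scatter). Compound 3 returns the halogen to the position it holds in compound 1 while changing it from bromine to fluorine, so only a shift within the scatter is expected in this assay, in either direction, a number 4 percentage points higher from compound 2 to compound 3 (within the scatter). Compound 3 is therefore expected to give about 57% in this assay, with a range from 42% to 72%.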

Compound 3, percent growth inhibition at one concentration: 32%
Compound 3: middle estimate off by 25 percentage points, on the high side, and the stated range ends above it.
By their numbers in this assay, from the lowest: compound 3; then compounds 2 and 1 (each within the scatter of the next).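

With the halogen on the 2-bromophenyl group exchanged for the one in 2-fluorophenyl, fluoro in place of bromo on an aromatic carbon gives a number 28 percentage points lower from compound 1 to compound 3 (beyond the scatter) in this assay and shows that, among these compounds, the identity of the halogen can change growth inhibition at the concentration tested, which the two bromine compounds alone could not reveal. The change from 4-bromobenzyl to 2-fluorobenzyl likewise gives a number 21 percentage points lower from compound 2 to compound 3 (beyond the scatter) while the move of bromine alone gave a number 7 percentage points lower from compound 1 to compound 2 (within the scatter) so both bromine compounds stand apart from the fluorine compound, and compound 3 is the only one of the three separated from the others. Nothing shown gives a reason for this separation.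

The compounds shown leave open whether a 2-chlorophenyl group would stay with the bromine compounds or fall toward compound 3, and whether a 4-fluorophenyl group would behave as 2-fluorophenyl does. They also leave open what a benzyl ring carrying a methoxy group or an amine in place of the halogen would give in this assay on the same shared core.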